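The source may report more compounds than this note shows. Statements on the series, on what has been measured and on what is new or still open speak of the compounds shown alone.

Three compounds sharing one core have been measured in a functional assay on HeLa cells (Homo sapiens) for inhibition, read by MTT assay, with a stated time of 48 h; on this read-out higher numbers stand for weaker inhibition and lower numbers for stronger inhibition:

Compound 1, `CCOC(=O)c1c(N)sc(/N=C/c2ccc([N+](=O)[O-])cc2)c1C(=O)OCC`: 14100 nM
Compound 2, `CCOC(=O)c1c(N)sc(/N=C/c2ccc(Cl)cc2)c1C(=O)OCC`: 25200 nM
Compound 3, `CCOC(=O)c1c(N)sc(/N=C/c2ccc(C)cc2)c1C(=O)OCC`: 41900 nM

Compound 1 has the lowest of the three numbers, and so the strongest inhibition among them. Its gap to compound 2, a 1.8-fold higher number from compound 1 to compound 2 (0.25 log units; within the scatter), lies within the scatter, so the two cannot be ranked with confidence. Its gap to compound 3, a 3.0-fold higher number from compound 1 to compound 3 (0.47 log units; beyond the scatter), is modest but real. Between compound 2 and compound 3 the step of a 1.7-fold higher number from compound 2 to compound 3 (0.22 log units; within the scatter) is again within the scatter.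

Compound 4, `CCOC(=O)c1c(N)sc(/N=C/c2ccco2)c1C(=O)OCC`, is not yet measured. It differs from compound 1 in one place: furan-2-yl in place of 4-nitrophenyl on a carbon with a double bond to nitrogen. The three measured steps all exchange one group on the same six-membered ring of carbon only, and every departure from the nitro group raised the number; the largest of them, a 3.0-fold higher number from compound 1 to compound 3 (0.47 log units; beyond the scatter), stayed modest. None of them exchanges the ring itself for a five-membered aromatic ring with one hetero atom, so the bearing of these steps on compound 4 is indirect. Since the nitro-bearing compound 1 sits at the low end, a step towards a higher number is expected, of roughly the size seen for compound 3.

Compound 4 is therefore estimated at 30000 nM, with a range from 10000 nM to 90000 nM, which means an expected step of a 2.1-fold higher number from compound 1 to compound 4 (0.33 log units; beyond the scatter).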

Compound 4, half-maximal inhibitory concentration: 46700 nM
Beside the measured number, compound 4's estimate is 1.6-fold (0.19 log units) below it; the measured number falls inside the stated range.
By their numbers in this assay, from the lowest: compounds 1, 2, 3 and 4 (each within the scatter of the next, the first and the last beyond it).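

In this assay, the step at this carbon with a double bond to nitrogen is a 3.3-fold higher number from compound 1 to compound 4 (0.52 log units; beyond the scatter). Unlike the earlier steps, this one replaces the whole 4-nitrophenyl with furan-2-yl, a smaller five-membered aromatic ring with one hetero atom, and the change remains modest. The other two comparisons, a 1.1-fold higher number from compound 3 to compound 4 (0.05 log units; within the scatter) and a 1.9-fold higher number from compound 2 to compound 4 (0.27 log units; within the scatter), show that furan-2-yl cannot be told apart from 4-methylphenyl or 4-chlorophenyl here, and no supporting data are available to explain any of these steps.

The compounds shown leave open whether a nitro group carried on the furan ring would give a lower number than compound 4 does, which would help separate the part played by the nitro group from that of the ring carrying it. They also leave open how a pyridine ring, a thiophene ring or a plain alkyl chain would compare with 4-nitrophenyl at this place, and whether an amine or a carboxylic acid on the aromatic ring would fit the small differences seen so far.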